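Adding a Methoxy Group to the Aryl Ring

The source may hold more compounds than are shown below. What is called first, only, known or untested is meant among the compounds shown, and "the series" means these compounds.

Compound 1 `CCOC(=O)[C@@H]1CC(=O)c2sccc2[C@H]1c1ccc(OC)cc1` gives 23.9% in a physicochemical assay, read by spectrophotometry, with a stated time of 20 min, tested at 80 ug/mL (on this read-out higher numbers stand for a stronger effect at the one concentration tested and lower numbers for a weaker effect), the lowest of the two numbers recorded, with its nearest neighbour compound 2 `CCOC(=O)[C@@H]1CC(=O)c2sccc2[C@H]1c1ccc(OCC)cc1` at 25.4%. Going by the values given here, the single measured step, a number 1.5 percentage points higher from compound 1 to compound 2 (within the scatter), concerns the chain on the ring oxygen, not the ring itself. Compound 3 `CCOC(=O)[C@@H]1CC(=O)c2sccc2[C@H]1c1ccc(OC)c(OC)c1` differs from compound 1 by methoxy in place of hydrogen on an aromatic carbon. Among the compounds with values here, no measured step bears directly on this change, so the estimate rests on the narrow spread seen so far. Compound 3 is expected to give 26% in this assay, between 12% and 40%, a step of a number 2.1 percentage points higher from compound 1 to compound 3 (within the scatter) that is expected to stay within the scatter.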

Compound 3, a percentage reported as activity, at one concentration (the size of the read-out at that concentration, not a potency): 22.9%
Beside the measured number, compound 3's estimate is 3.1 percentage points above it, within the range that was stated.
By their numbers in this assay, from the lowest: compounds 3, 1 and 2 (each within the scatter of the next).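

In this assay, methoxy in place of hydrogen on an aromatic carbon, ortho to a methoxy group, gives a number 1 percentage points lower from compound 1 to compound 3 (within the scatter) and so leaves the read-out indistinguishable from that of compound 1. Going by these compounds alone, this is the first step that changes the aromatic ring itself rather than the chain on its oxygen, and it shows that this added group produces no change beyond the scatter at this position. Nothing available explains this result.

As far as these compounds go, whether an amine, a carboxylic acid or a longer chain on this carbon would also stay within the scatter remains open. So does whether any change to this ring can raise the read-out beyond the scatter.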